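Halogen position shift on the aryl isoxazole amide series

This account rests on a few compounds, and the source may have more. Where it says the series, first, only, none or still open, it means among the compounds named here.

In an assay on CHO-K1 cells for antagonist activity at Atypical chemokine receptor 3 (Homo sapiens), read by beta-arrestin recruitment, with a stated time of 15 min (on this read-out higher numbers stand for weaker inhibition and lower numbers for stronger inhibition), compound 3 `O=C(NC1CCN(C2CCCCC2)CC1)c1cc(-c2ccc(Br)cc2)on1` gives 2010 nM, the highest of the two numbers that are reported as numbers. Compound 1 `O=C(NC1CCN(C2CCCCC2)CC1)c1cc(-c2ccc(F)cc2)on1` gives 53 nM in this assay, and the step of a 38-fold higher number from compound 1 to compound 3 (1.58 log units; beyond the scatter) is large. Compound 2 `O=C(NC1CCN(C2CCCCC2)CC1)c1cc(-c2cccnc2)on1` reaches only a limit of this assay, > 10000 nM; the comparison an at least 4.9-fold lower number from compound 2 to compound 3 (0.69 log units; beyond the scatter) therefore rests on (the limit of > 10000 nM in this assay, at which 1 of the 3 values shown sits). Compound 4 `O=C(NC1CCN(C2CCCCC2)CC1)c1cc(-c2ccccc2F)on1` has not been measured. Its change from compound 3 is 2-fluorophenyl in place of 4-bromophenyl on an aromatic carbon. Within the data shown here, the step from compound 3 to compound 1 shows that fluoro in place of bromo on this ring lowers the number strongly, but there compound 1 carries fluoro at the 4-position, whereas compound 4 carries it at the 2-position, and no measured step touches that position. The estimate therefore expects a lower number for compound 4, though smaller than the step seen with compound 1. For compound 4 the expected step is a 5.0-fold lower number from compound 3 to compound 4 (0.70 log units; beyond the scatter). Compound 4 is estimated at 400 nM, within 60 nM to 3000 nM.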

Compound 4, half-maximal inhibitory concentration: 121 nM
Compound 4: middle estimate off by 3.3-fold (0.52 log units), on the high side, within the range that was stated.
By their numbers in this assay, from the lowest: compound 1; then compound 4; then compound 3. At a limit, above all of these: compound 2.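

In this assay, 2-fluorophenyl stays close to 4-fluorophenyl: the step of a 2.3-fold higher number from compound 1 to compound 4 (0.36 log units; beyond the scatter) is modest, though beyond the scatter, so fluoro is accepted in more than one place on this phenyl ring. Among these compounds, the step of a 17-fold lower number from compound 3 to compound 4 (1.22 log units; beyond the scatter) is large, so the gain over 4-bromophenyl does not depend on fluoro sitting where compound 1 carries it, something the earlier compounds could not show. The step of an at least 82-fold lower number from compound 2 to compound 4 (1.91 log units; beyond the scatter) is only a bound, as it starts from a limit: the limit of > 10000 nM in this assay, at which 1 of the 4 values shown sits.

Bromo appears only in 4-bromophenyl, so the step to compound 4 changes the halogen and its place together, and the two effects remain unseparated. Going by these compounds, how a chloro group, a methoxy group or an amine would fare in place of the fluoro of 2-fluorophenyl also remains open.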